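Dropping the fluoro group from compound 2

The compounds below may be only part of what the source reports. "The series", "measured", "known", "first", "only" and "open" are said of these compounds alone.

Measured in a toxicity assay on L02 cells (Homo sapiens) for cytotoxicity, read by MTT assay, with a stated time of 72 h; a higher number here means a weaker inhibitor, a lower number a stronger inhibitor:
compound 1 `C=CC(=O)N1CCC(Oc2nc(Nc3ccc(N4CCN(C)CC4)cc3OC)nc3[nH]ccc23)CC1`: 18000 nM
compound 2 `C=CC(=O)N1CCC(Oc2nc(Nc3ccc(N4CCN(C)CC4)c(F)c3)nc3[nH]ccc23)CC1`: 1890 nM

Of the two, compound 2 has the lower number, and the gap up to compound 1 lies beyond the usual scatter. Compound 3 `C=CC(=O)N1CCC(Oc2nc(Nc3ccc(N4CCN(C)CC4)cc3)nc3[nH]ccc23)CC1` has not yet been measured. It differs from compound 2 by hydrogen in place of fluoro on an aromatic carbon, ortho to a 4-methylpiperazin-1-yl group. For the measured compounds named here, no measured pair shows this change alone, so the frame is loose. The expectation rests only on compound 2 at 1890 nM and compound 1 at 18000 nM. In this assay the expected move is upward, an estimated 2.4-fold higher number from compound 2 to compound 3 (0.38 log units; beyond the scatter), and it may not clear the scatter. The estimate for compound 3 is 4500 nM, with an expected range of 1500 nM to 14000 nM.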

Compound 3, half-maximal inhibitory concentration: 6250 nM
For compound 3 the middle estimate is 1.4-fold (0.14 log units) below the measured one; the measured number falls inside the stated range.
By their numbers in this assay, from the lowest: compound 2; then compound 3; then compound 1.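

In this assay, for the compounds shown here, replacing fluoro with hydrogen ortho to a 4-methylpiperazin-1-yl group gives a 3.3-fold higher number from compound 2 to compound 3 (0.52 log units; beyond the scatter), the first single-change reading at this position, and it shows that fluoro here carries the lower number of the pair. Replacing methoxy with hydrogen gives a 2.9-fold lower number from compound 1 to compound 3 (0.46 log units; beyond the scatter), so with hydrogen as the shared reference, the two substituents, at their separate places on the ring, move the number in opposite directions by modest steps. No measurement at hand accounts for either step.

On these data alone, whether chloro, methyl or a nitrile at the fluoro position would follow fluoro or hydrogen remains open. Also open, as far as these compounds go, is whether the fluoro step would keep its size with a methoxy group elsewhere on the same ring.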